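Lengthening the chain toward a longer hydroxamic acid

The source may report more compounds than this note shows. Statements on the series, on what has been measured and on what is new or still open speak of the compounds shown alone.

Compound 1 `Nc1ncnc2c1c(-c1cnc3[nH]ccc3c1)nn2CCCC(=O)NO` carries a hydroxycarbamoyl group on a short saturated chain attached to its core. On these data alone, in a functional assay on HeLa cells (Homo sapiens) for inhibition, read by MTT assay, with a stated time of 72 h (on this read-out lower numbers stand for stronger inhibition and higher numbers for weaker inhibition), compound 1 stands at "not determined" (no result reported), so its own position on this read-out is unknown. Two related compounds give a sense of the scale. Compound 2 `Nc1nc2cc(-c3nn(CCCCCC(=O)NO)c4ncnc(N)c34)ccc2o1`, which bears a longer chain on a different core, gives 15400 nM in this assay. Compound 3 `Nc1ncnc2c1c(-c1cnc3[nH]ccc3c1)nn2CCCCCCC(=O)NO` shares the core of compound 1 but has a longer chain; in this assay compound 3 gives 22000 nM. These two values lie within the usual scatter of each other, so neither can be called stronger.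

Compound 4 `Nc1ncnc2c1c(-c1cnc3[nH]ccc3c1)nn2CCCCCCCCC(=O)NO` is the next member of the series, differing from compound 1 as follows: 5-(hydroxycarbamoyl)pentyl in place of hydroxycarbamoyl on a saturated chain carbon, three bonds along the chain from an aromatic nitrogen. With no number for compound 1, the size and direction of the step from compound 1 to compound 4 in this assay cannot be drawn from the measurements; only the values of compound 2 and compound 3 offer a point of reference. On that basis compound 4 is expected to give about 12000 nM in this assay, with a likely range from 3000 nM to 40000 nM.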

Compound 4, half-maximal inhibitory concentration: 7470 nM
For compound 4 the middle estimate is 1.6-fold (0.21 log units) above the measured one, within the range that was stated.
By their numbers in this assay, from the lowest: compound 4; then compounds 2 and 3 (each within the scatter of the next).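

On the shared core, with only the chain changing, lengthening it gives a 2.9-fold lower number from compound 3 to compound 4 (0.47 log units; beyond the scatter) in this assay. Among the compounds shown here, this is the first comparison here in which a single change moves the number beyond the usual scatter: 2-(hydroxycarbamoyl)ethyl in place of hydroxycarbamoyl on a saturated chain carbon, six bonds along the chain from an aromatic nitrogen. It shows that the hydroxamic acid chain can be extended at this position without loss on this read-out, and that chain length alone can shift the result, though only modestly and on the evidence of a single pair of compounds; no measurement here explains why the longer chain goes with the lower number.

Steps from compound 1 cannot be read, since it has no number, so two chain lengths on this core cannot establish a trend. The compounds shown leave open whether a longer chain than that of compound 4 would lower the number further or raise it again, and whether the hydroxamic acid itself is needed, which a carboxylic acid at the same chain end would test.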